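Cyano for Trifluoromethoxy: Expectation for Compound 4

The compounds below may be only part of what the source reports. "The series", "measured", "known", "first", "only" and "open" are said of these compounds alone.

Compound 3 `O=C(Nc1ccc(Cl)cc1)Nc1cc(C2CC2)nn1-c1ccc(OC(F)(F)F)cc1` was tested in an assay on isolated protein for inhibition of Ephrin type-A receptor 2 (Homo sapiens), read by thermal shift assay, tested at 10 uM (a higher number here means that the compound stabilises the target more against heat, a lower number that the compound stabilises the target less), where compound 3 gives 0.2 degrees C. Its two neighbours sit close by: compound 1 `CC(C)(C)c1cc(NC(=O)Nc2ccc(Cl)cc2)n(-c2ccc(OC(F)(F)F)cc2)n1` gives 0.9 degrees C and compound 2 `CC(C)(C)c1cc(NC(=O)Nc2ccc(Cl)cc2)n(-c2ccc(C#N)cc2)n1` gives 0.8 degrees C, and both of these differences lie within the usual scatter, as the step of a number 0.70 degrees C lower from compound 1 to compound 3 (within the scatter) shows.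

Compound 4 `N#Cc1ccc(-n2nc(C3CC3)cc2NC(=O)Nc2ccc(Cl)cc2)cc1` differs from compound 3 by cyano in place of trifluoromethoxy on an aromatic carbon. The same exchange has already been made once in this set, and there it produced a number 0.10 degrees C lower from compound 1 to compound 2 (within the scatter). On that basis no movement beyond the scatter is expected in this assay. The expected step is a number 0.10 degrees C lower from compound 3 to compound 4 (within the scatter). Compound 4 is therefore estimated at 0.1 degrees C, with a likely range from -0.8 degrees C to 1 degrees C.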

Compound 4, shift of the target's melting temperature: 0.5 degrees C
Beside the measured number, compound 4's estimate is 0.40 degrees C below it, and the stated range covers the measured number.
By their numbers in this assay, from the lowest: compounds 3, 4, 2 and 1 (each within the scatter of the next).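

In this assay the exchange of cyano for trifluoromethoxy now has a reading on a second core, which gives a number 0.30 degrees C higher from compound 3 to compound 4 (within the scatter) and stays close to the first reading: the same change on two cores in this assay, a number 0.10 degrees C lower (within the scatter) from compound 1 to compound 2 and a number 0.30 degrees C higher (within the scatter) from compound 3 to compound 4, 0.40 degrees C apart, within the scatter of two such steps. The exchange of cyclopropyl for tert-butyl also has a second reading, which gives a number 0.30 degrees C lower from compound 2 to compound 4 (within the scatter) and likewise stays close to the first: the same change on two cores in this assay, a number 0.70 degrees C lower (within the scatter) from compound 1 to compound 3 and a number 0.30 degrees C lower (within the scatter) from compound 2 to compound 4, 0.40 degrees C apart, within the scatter of two such steps. Neither exchange stands clear of the scatter on either core. Going by these compounds, it remains open whether any group at these places would shift the number beyond the scatter. An amine or a carboxylic acid in place of the cyano, or a longer chain in place of the cyclopropyl, would test this.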